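The Mirror Image of a Methylated Amine: What to Expect

The source may report more compounds than this note shows. Statements on the series, on what has been measured and on what is new or still open speak of the compounds shown alone.

Compound 1 `CN1C[C@H]2C=C(c3cccnc3)C[C@H](C2)C1` was tested in an in vitro functional assay on SH-EP1 cells for agonist activity at Neuronal acetylcholine receptor; alpha4/beta2 (Homo sapiens), read by FLIPR and calcium flux; a higher number here means that more compound is needed for the effect, a lower number that less compound is needed. In this assay compound 1 reaches only the limit of > 10000 nM, so no true value for it is known. It is one of the compounds sitting at the limit of > 10000 nM in this assay, at which 1 of the 3 values shown sits. Its closest measured relative, compound 2 `C1=C(c2cccnc2)C[C@H]2CNC[C@@H]1C2`, carries a hydrogen instead of a methyl on the ring amine nitrogen and gives 2.3 nM. That single change is measured as an at least 4300-fold lower number from compound 1 to compound 2 (3.63 log units; beyond the scatter). Compound 3 `C1=C(c2cncnc2)CC2CNCC1C2`, which has a different aromatic ring and no defined configuration, gives 240 nM.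

Compound 4 `CN1C[C@@H]2C=C(c3cccnc3)C[C@@H](C2)C1` has not been measured. It is the mirror image of compound 1: the two compounds have the same atoms and bonds and differ only in configuration as drawn: 2 of 2 stereo elements differ (all stereocentres are inverted: mirror images); a stereocentre at a saturated ring carbon is drawn R in compound 1 and S in compound 4; a stereocentre at a saturated ring carbon is drawn S in compound 1 and R in compound 4. No measured pair differs only in configuration, so no measured step speaks directly to this change; the one step shown concerns the methyl on the amine nitrogen, and it was very large. Compound 4 keeps that methyl, which in compound 1 accompanies a result at the limit. The expected step is therefore small, a number no higher from compound 1 to compound 4 (the limit leaves the size open), with a real chance that the assay again reports only a limit. Compound 4 is estimated at 10000 nM, within a range from 1000 nM to 100000 nM.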

Compound 4, half-maximal effective concentration: 6660 nM
Beside the measured number, compound 4's estimate is 1.5-fold (0.18 log units) above it; the measured number falls inside the stated range.
By their numbers in this assay, from the lowest: compound 2; then compound 3; then compound 4. At a limit, above all of these: compound 1.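

In this assay compound 4 gives a true number, 6660 nM, so this methylated amine can now be read as a measured value in one of its two mirror forms. Compound 1 remains at a limit, and its true value stays unknown: the limit of > 10000 nM in this assay, at which 1 of the 4 values shown sits. Inverting both stereocentres gives an at least 1.5-fold lower number from compound 1 to compound 4 (0.17 log units; that floor lies within the scatter), a floor that does not by itself show a real difference, although any gap in this pair could come only from configuration: the fact that compounds 1 and 4 differ only in the configuration as drawn

It remains open how much configuration counts when the ring amine carries hydrogen instead of methyl, as it does in compound 2, whose mirror image does not appear among the compounds shown. Also open, from the compounds shown here alone, is whether an ethyl group or an acetyl group on that same nitrogen would behave like the methyl, and whether the two mirror forms would then draw apart or stay as hard to separate as compound 1 and compound 4 are here.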